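This account rests on a few compounds, and the source may have more. Where it says the series, first, only, none or still open, it means among the compounds named here.

Working notes on the series. The three measured compounds share one core and differ only in the group on the amide-type nitrogen. Compound 1 `COc1cc(Nc2ncnc3c(NC(=O)Nc4cc(Cl)c(Cl)cc4Cl)cccc23)cc(OC)c1` carries 2,4,5-trichlorophenyl there, and in a functional assay on RT-112 cells (Homo sapiens) for antiproliferative activity, read by MTT assay, with a stated time of 72 h (a lower number here means a stronger inhibitor of growth, a higher number a weaker inhibitor of growth), compound 1 gives 4890 nM. Compound 2 `COc1cc(Nc2ncnc3c(NC(=O)Nc4ccc(Cl)c(C(F)(F)F)c4)cccc23)cc(OC)c1` carries 4-chloro-3-(trifluoromethyl)phenyl; in this assay compound 2 reaches only a limit, > 20000 nM (the limit of > 20000 nM in this assay, at which 1 of the 3 values shown sits). Compound 3 `COc1cc(Nc2ncnc3c(NC(=O)Nc4cc(C)cc(C)c4)cccc23)cc(OC)c1` carries 3,5-dimethylphenyl, and in this assay compound 3 gives 10100 nM. Of the two actual numbers compound 3 stands highest: a 2.1-fold higher number from compound 1 to compound 3 (0.32 log units; beyond the scatter). The remaining steps are an at least 4.0-fold higher number from compound 1 to compound 2 (0.61 log units; beyond the scatter) and an at least 1.9-fold lower number from compound 2 to compound 3 (0.29 log units; that floor lies within the scatter).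

Compound 4 `COc1cc(Nc2ncnc3c(NC(=O)c4ccc(CN(C)C)cc4)cccc23)cc(OC)c1` is not yet measured. It alters the linkage itself: 4-((dimethylamino)methyl)phenyl in place of (3,5-dimethylphenyl)amino on a carbonyl carbon. Among the compounds with values here, none of the measured steps touches the carbonyl carbon; each swaps only the ring on the nitrogen, and among the real numbers those swaps moved the result by a 2.1-fold higher number from compound 1 to compound 3 (0.32 log units; beyond the scatter). Within the data shown here, they bear on the new step only by showing that changes at this end of the molecule have so far produced modest shifts and no strong compound. Among the measured compounds shown here, there is no precedent for the loss of the donor and the entry of the dimethylaminomethyl group, so the expected step is a 1.3-fold lower number from compound 3 to compound 4 (0.10 log units; within the scatter), with a wide band around it. Compound 4 is therefore expected to give about 8000 nM in this assay, between 2000 nM and 30000 nM.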

Compound 4, concentration for 50% growth inhibition: 4370 nM
Estimate against measurement, compound 4: 1.8-fold (0.26 log units) above; the range from low to high includes it.
By their numbers in this assay, from the lowest: compounds 4 and 1 (each within the scatter of the next); then compound 3. At a limit, above all of these: compound 2.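

Within the data shown here, the linkage itself can change without loss: with 4-((dimethylamino)methyl)phenyl in place of (3,5-dimethylphenyl)amino on the carbonyl carbon, this assay shows a 2.3-fold lower number from compound 3 to compound 4 (0.36 log units; beyond the scatter), and this is the first measured change at this carbon rather than on the ring carried by the amide-type nitrogen. The amide-type nitrogen on that side of the carbonyl is therefore not needed to reach the level of the best earlier compound, as the comparison with the trichlorophenyl compound gives a 1.1-fold lower number from compound 1 to compound 4 (0.05 log units; within the scatter), and neither of those two compounds stands ahead of the other. Compound 2 stands at a limit, not a number, so its step is only a floor, an at least 4.5-fold lower number from compound 2 to compound 4 (0.66 log units; beyond the scatter), and nothing on hand accounts for any of these shifts.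

The change removes the (3,5-dimethylphenyl)amino group and brings in the dimethylaminomethyl group in one step, so the two contributions cannot be told apart here. A plain phenyl on the carbonyl carbon would separate them, while a morpholine or piperazine in place of the dimethylamino group would show whether that amine matters at all.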